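Hydroxy in Place of Amino at the Chain End

The source may hold more compounds than are shown below. What is called first, only, known or untested is meant among the compounds shown, and "the series" means these compounds.

Measured compounds:
compound 1, `O=C(O)[C@@H]1CCCN1C(=O)CN(c1nc(Cl)nc2[nH]cnc12)C1CC1`: 7.29%
compound 2, `NC(=O)C[C@H](NC(=O)CN(c1nc(Cl)nc2[nH]cnc12)C1CC1)C(=O)O`: 7.51%
compound 3, `CSCC[C@H](NC(=O)CN(c1nc(Cl)nc2[nH]cnc12)C1CC1)C(=O)OCc1ccccc1`: 17.6%

The three compounds share a core and were tested in a functional assay on the whole organism (Tail, strain ICR) with Mus musculus as the target, in the tail flick test, with a stated time of 150 min, at a dose of 25 umol/kg by the oral route; on this read-out lower numbers stand for a weaker effect and higher numbers for a stronger effect at the one dose given. Compound 2 gives 7.51%. Compound 1 gives 7.29%, a number within the scatter of that of compound 2, so no difference between these two can be claimed. Within the data shown here, compound 3 gives 17.6%, which lies beyond the scatter above compound 2; no single structural step links compound 3 to compound 2, so this gap is only noted.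

Compound 4, `O=C(O)C[C@H](NC(=O)CN(c1nc(Cl)nc2[nH]cnc12)C1CC1)C(=O)O`, has not been measured. It differs from compound 2 in one place: hydroxy in place of amino on a carbonyl carbon. Both remaining groups carry one hydrogen-bond donor, and the change adds no ring and no charge. Among the measured compounds shown here, nothing among the measured compounds shows what such a change does. The expected step of a number 0 percentage points lower from compound 2 to compound 4 (within the scatter) is small, in no particular direction, and within the scatter. Compound 4 is therefore estimated at 7.5%, with a range from 0% to 17%.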

Compound 4, a percentage reported as activity, at one dose (the size of the read-out at that dose, not a potency): 11.6%
Beside the measured number, compound 4's estimate is 4.1 percentage points below it, within the range that was stated.
By their numbers in this assay, from the lowest: compounds 1, 2, 4 and 3 (each within the scatter of the next, the first and the last beyond it).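

Among these compounds, the swap of carbamoyl to carboxy gives the first direct look at this position: in this assay, hydroxy in place of amino on a carbonyl carbon gives a number 4.1 percentage points higher from compound 2 to compound 4 (within the scatter). At this one dose, the two groups cannot be told apart, so the exchange at this chain end brings neither a gain nor a loss that can be claimed. No separate measurement bears on the reason for this result.

Going by these compounds, whether a methyl ester or a primary amine at this chain end, or a longer chain carrying the carboxy group, would shift the number beyond the scatter remains open. On these data alone, the outcome of the same exchange at other oral doses is also open: a percentage at one dose is not a potency.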